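This account rests on a few compounds, and the source may have more. Where it says the series, first, only, none or still open, it means among the compounds named here.

Compound 3, with structure `COc1cccc(C(=O)NNC(=O)c2ccc3[nH]c(-c4ccc([N+](=O)[O-])o4)nc3c2)c1`, is measured in an ADME assay on Vero cells (Chlorocebus sabaeus) for inhibition, read by sulforhodamine B assay, with a stated time of 48 h (a higher number here means a weaker inhibitor of growth, a lower number a stronger inhibitor of growth), at 31.3 ug/mL, the lowest of the two plain numbers shown. Its nearest neighbour is compound 1, structure `COc1ccc(C(=O)NNC(=O)c2ccc3[nH]c(-c4ccc([N+](=O)[O-])o4)nc3c2)cc1OC`, which in this assay gives 62.5 ug/mL; the step of a 2.0-fold lower number from compound 1 to compound 3 (0.30 log units; within the scatter) is within the scatter. Compound 2, structure `COc1cccc(C(=O)NNC(=O)c2ccc3[nH]c(-c4ccc([N+](=O)[O-])s4)nc3c2)c1`, reaches only a limit of the assay, > 250 ug/mL. Among the measured compounds shown here, the step of an at least 7.9-fold lower number from compound 2 to compound 3 (0.90 log units; beyond the scatter) is beyond the scatter, and it is the only change of that size among the measured pairs; it involves the limit (the limit of > 250 ug/mL in this assay, at which 1 of the 3 values shown sits).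

Compound 4, structure `O=CNNC(=O)c1ccc2[nH]c(-c3ccc([N+](=O)[O-])o3)nc2c1`, is not yet measured. It differs from compound 3 by hydrogen in place of 3-methoxyphenyl on a carbonyl carbon. Neither measured step touches this carbonyl carbon, so no direct guide exists; the closest measured change, removing a methoxy from an aromatic carbon, stayed within the scatter. A step of modest size at most is therefore expected, with no firm direction. The expected step from compound 3 is a 1.4-fold higher number from compound 3 to compound 4 (0.16 log units; within the scatter), giving compound 4 an estimated 45 ug/mL, between 15 ug/mL and 125 ug/mL.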

Compound 4, concentration for 50% growth inhibition: 62.5 ug/mL
Compound 4: middle estimate off by 1.4-fold (0.14 log units), on the low side, within the range that was stated.
By their numbers in this assay, from the lowest: compounds 3, 1 and 4 (each within the scatter of the next). At a limit, above all of these: compound 2.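

The change from (3-methoxyphenyl)carbonyl to formyl is the first one shown at this carbonyl carbon, and in this assay it gives a 2.0-fold higher number from compound 3 to compound 4 (0.30 log units; within the scatter) and so removes a whole aromatic ring with no step beyond the scatter. Hydrogen in place of 3,4-dimethoxyphenyl at the same carbon gives no change at the digits printed from compound 1 to compound 4 (within the scatter), so for these three compounds neither aryl group is needed to keep the number in this range. Nothing measured here gives a reason for this result.

On these data alone, it remains open whether a larger change at this carbonyl carbon, such as a longer alkyl chain, an amine or a carboxylic acid, would stay within the scatter too. Also open, as far as these compounds go, is whether 5-nitrothiophen-2-yl in place of 5-nitrofuran-2-yl would have the same effect in the formyl series.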